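A few compounds are considered here, and "the series" means these few. Any claim that something is new, unique, unknown or untested is made for them only; others in the source may bear on it.

Measured so far:
Compound 1 `Cc1nc(-c2ccccc2)c(C(=O)N2CCN(c3cccc(C(N)=O)c3)CC2)o1`: 71 nM
Compound 2 `Cc1nc(-c2ccccc2Cl)c(C(=O)N2CCN(c3cccc(Cl)c3)CC2)o1`: 132 nM

Both numbers come from a functional assay on HL-60 cells (Homo sapiens) for inhibition, read by MTT assay, with a stated time of 72 h; on this read-out higher numbers stand for weaker inhibition and lower numbers for stronger inhibition. On this read-out compound 1 gives 71 nM and compound 2 gives 132 nM; these two numbers lie within the usual scatter of each other, so neither compound can be called the stronger inhibitor from these measurements alone. Compound 3 `Cc1nc(-c2ccccc2)c(C(=O)N2CCN(c3cccc(F)c3)CC2)o1` has not yet been measured. It is derived from compound 1 by a single change: fluoro in place of carbamoyl on an aromatic carbon. For the measured compounds named here, compound 2 differs from compound 1 in two places at once, so its number cannot be tied to this one change, and no measured pair isolates it. With nothing to anchor a direction, only a small step is expected: the estimated step of a 1.7-fold higher number from compound 1 to compound 3 (0.23 log units; within the scatter) leans toward a higher number but stays within the scatter. Compound 3 is therefore expected to give 120 nM in this assay, with a likely range from 40 nM to 400 nM.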

Compound 3, half-maximal inhibitory concentration: 45 nM
Beside the measured number, compound 3's estimate is 2.7-fold (0.43 log units) above it; the measured number falls inside the stated range.
By their numbers in this assay, from the lowest: compounds 3, 1 and 2 (each within the scatter of the next, the first and the last beyond it).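

In this assay, for the compounds shown here, the swap of carbamoyl for fluoro on this aromatic carbon gives a 1.6-fold lower number from compound 1 to compound 3 (0.20 log units; within the scatter) and is the first single change at this position that can be read on its own, since compound 2 differs from the others in more than one place. The two numbers cannot be told apart on this read-out, even though a group of three heavy atoms with a hydrogen-bond donor and a hydrogen-bond acceptor gives way to a single fluorine atom with neither, so at this position in this assay the carbamoyl group's donor and acceptor are not needed to keep the number within the scatter. Nothing available here gives a reason for this result. 

Still open, on these data alone, is how far this holds, since one pair cannot show whether other groups at the same place, such as an amine, a carboxylic acid or a longer chain, would also leave the number within the scatter or move it beyond. It is also unknown whether the same swap would behave alike on a different version of the shared core, or in any other assay.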